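This account rests on a few compounds, and the source may have more. Where it says the series, first, only, none or still open, it means among the compounds named here.

Notes on the series in a functional assay on the whole organism (strain albino) for inhibition, with Rattus norvegicus as the target, read by paw edema, with stated times of 30 min and 1 h, at a dose of 100 mg/kg by the oral route; on this read-out higher numbers stand for more inhibition at the one dose given (going by the name of the read-out) and lower numbers for less inhibition.

Going by the values given here, compound 3, `COc1ccc(C2CC(c3ccc(OC)c(OC)c3)=NN2C(=O)C(C)O[N+](=O)[O-])c(OC)c1`, gives 44% in this assay, the highest of the three numbers so far. Compound 2, `COc1ccc(C2=NN(C(=O)C(C)O[N+](=O)[O-])C(c3ccco3)C2)cc1OC`, gives 35%, and the gap between them is within the scatter. Compound 1, `COc1ccc(C2=NNC(c3c(Cl)cccc3Cl)C2)cc1OC`, gives 26%, which lies beyond the scatter below compound 3.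

The next compound, compound 4, `COc1ccc(C2=NN(C(=O)C(C)O[N+](=O)[O-])C(c3c(Cl)cccc3Cl)C2)cc1OC`, differs from compound 3 in one place: 2,6-dichlorophenyl in place of 2,4-dimethoxyphenyl on a saturated ring carbon. Among the compounds with values here, the only single-point step measured on this saturated ring carbon is a number 9 percentage points higher from compound 2 to compound 3 (within the scatter), so exchanging the group at that position has not moved the number beyond the scatter. Compound 1 carries the same 2,6-dichlorophenyl group as compound 4 but differs from it in a further place, so its value is only a loose pointer toward the lower end.

On this basis no step beyond the scatter is expected; for compound 4 the estimated step is a number 10 percentage points lower from compound 3 to compound 4 (within the scatter), and compound 4 is expected to give about 34%, in the range 22% to 46%.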

Compound 4, a percentage reported as inhibition, in the whole organism at one dose (the size of the read-out at that dose, not a potency): 47%
Compound 4: middle estimate off by 13 percentage points, on the low side; the whole stated range lies below it.
By their numbers in this assay, from the lowest: compounds 1, 2, 3 and 4 (each within the scatter of the next, the first and the last beyond it).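

In this assay, going by these compounds alone, 2,6-dichlorophenyl and 2,4-dimethoxyphenyl on the saturated ring carbon cannot be told apart, with a number 3 percentage points higher from compound 3 to compound 4 (within the scatter), whereas replacing furan-2-yl with 2,6-dichlorophenyl gives the first step at this position that lies beyond the scatter, a number 12 percentage points higher from compound 2 to compound 4 (beyond the scatter). The series also now has a one-place change on the amine nitrogen in a ring: a group of 8 heavy atoms in place of a hydrogen atom gives a number 21 percentage points higher from compound 1 to compound 4 (beyond the scatter), so the number responds to that position as well. No measurement here accounts for either step.

Open, as far as these compounds go, is how an unsubstituted phenyl or a cyclohexyl group would stand on the saturated ring carbon. Also open, from the compounds shown here alone, is whether a plain acetyl group on the ring nitrogen, without the nitrate ester, would give a similar step.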